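Lengthening the amine chain on a piperidine amide

A few compounds are considered here, and "the series" means these few. Any claim that something is new, unique, unknown or untested is made for them only; others in the source may bear on it.

Three compounds share a core that carries a sulfonamide linked to a piperidine whose nitrogen bears a small amide. Compound 1 `CC(=O)N1CCC(NS(=O)(=O)c2ccc(NC(=O)c3ccccc3C)c3ccccc23)CC1` gives 6.7 nM in an assay on L1.2 cells for binding affinity to C-C chemokine receptor type 8 (Homo sapiens); on this read-out higher numbers stand for weaker inhibition and lower numbers for stronger inhibition. Compound 2 `Cc1ccccc1C(=O)Nc1ccc(S(=O)(=O)NC2CCN(C(=O)CO)CC2)c2ccccc12` gives 5.4 nM in this assay, and compound 3 `Cc1ccccc1C(=O)Nc1ccc(S(=O)(=O)NC2CCN(C(=O)CCN)CC2)c2ccccc12` gives 11.3 nM. Compound 3 thus shows the highest of the three numbers: the step of a 1.7-fold higher number from compound 1 to compound 3 (0.23 log units; within the scatter) stays within the scatter, while the step of a 2.1-fold higher number from compound 2 to compound 3 (0.32 log units; beyond the scatter) just passes beyond it.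

Compound 4 `Cc1ccccc1C(=O)Nc1ccc(S(=O)(=O)NC2CCN(C(=O)CCCCN)CC2)c2ccccc12` differs from compound 3 by 2-aminoethyl in place of amino on a saturated chain carbon, two bonds along the chain from a carbonyl carbon, so the amine is simply moved further out along the chain. Within the data shown here, no measured pair tests such a chain lengthening directly; the closest comparisons, the steps from compound 1 and compound 2 to compound 3, were small. A change of similar modest size, or none beyond the scatter, is therefore expected in this assay, with no clear direction. Compound 4 is estimated at 12 nM, with a likely range from 4 nM to 36 nM, meaning an expected step of a 1.1-fold higher number from compound 3 to compound 4 (0.03 log units; within the scatter).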

Compound 4, inhibition constant: 199 nM
Compound 4: the middle estimate sits 17-fold (1.22 log units) below what was measured, outside the stated range (above it).
By their numbers in this assay, from the lowest: compounds 2, 1 and 3 (each within the scatter of the next, the first and the last beyond it); then compound 4.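

The earlier steps shown here on the carbon bound to the carbonyl carbon were small, which made this position look tolerant of hydrogen, hydroxy or aminomethyl, but in this assay the longer chain shows a clear limit, with an 18-fold higher number from compound 3 to compound 4 (1.25 log units; beyond the scatter). The drop is just as large against the other two compounds, with a 37-fold higher number from compound 2 to compound 4 (1.57 log units; beyond the scatter) and a 30-fold higher number from compound 1 to compound 4 (1.47 log units; beyond the scatter), so 3-aminopropyl stands apart from all three shorter groups at this position. Nothing measured here explains why this longer amine chain gives so much weaker inhibition.

From the compounds shown here alone, it remains open whether the number climbs gradually or abruptly with length, which 2-aminoethyl on that same carbon would help to show. Going by these compounds, it is also open whether chain length alone matters or the amine at its end does too, a question that a plain butyl chain or 3-hydroxypropyl could address.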